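A Pyridine in Place of 4-Chlorophenyl

This account rests on a few compounds, and the source may have more. Where it says the series, first, only, none or still open, it means among the compounds named here.

Compound 1 `CC(C)(C)C(=O)N1Cc2c(NC(=O)c3cccnc3)n[nH]c2C1(C)C` gives 690 nM
Compound 2 `CN1CCC(C(=O)N2Cc3c(NC(=O)c4ccc(Cl)cc4)n[nH]c3C2(C)C)CC1` gives 120 nM

In a functional assay on A2780 cells (Homo sapiens) for antiproliferative activity, read by fluorescence, with a stated time of 72 h (on this read-out lower numbers stand for stronger inhibition and higher numbers for weaker inhibition), compound 2 holds the lower of the two numbers at 120 nM and so shows the stronger inhibition. The gap to compound 1 at 690 nM lies beyond the scatter.

Going by the values given here, in compound 3 `CN1CCC(C(=O)N2Cc3c(NC(=O)c4ccncc4)n[nH]c3C2(C)C)CC1` the only change from compound 2 is pyridin-4-yl in place of 4-chlorophenyl on a carbonyl carbon. Among the compounds with values here, no pair of measured compounds isolates this change, so any forecast is uncertain. Compound 1 (690 nM) also lacks the 4-chlorophenyl and has the higher number, but it differs from compound 2 in more than one place and offers only a loose guide. On that slender basis, a move toward weaker inhibition in this assay is expected, probably beyond the scatter, with an estimated step of a 3.3-fold higher number from compound 2 to compound 3 (0.52 log units; beyond the scatter) in that direction. Compound 3 is expected at about 400 nM in this read-out. The estimated range for it runs from 130 nM to 1200 nM and remains wide.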

Compound 3, half-maximal inhibitory concentration: 500 nM
Estimate against measurement, compound 3: 1.3-fold (0.10 log units) below; low and high end bracket the measured number.
By their numbers in this assay, from the lowest: compound 2; then compounds 3 and 1 (each within the scatter of the next).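

In this assay, pyridin-4-yl in place of 4-chlorophenyl on a carbonyl carbon gives a 4.2-fold higher number from compound 2 to compound 3 (0.62 log units; beyond the scatter) and thus a modest loss of inhibition, so this position does respond to the group it carries. Compound 2 and compound 3 differ in this one place alone, which the earlier pair of compound 1 and compound 2 did not offer, and the step therefore belongs to this exchange of a carbon-only aromatic ring bearing chlorine for an aromatic ring with one hetero atom and one hydrogen-bond acceptor. The data shown offer no measurement that explains the step.

Going by these compounds, whether the step comes from losing the chlorine or from gaining the ring nitrogen stays open, and a plain phenyl or a 4-methoxyphenyl on the same carbonyl carbon would help to separate the two. Also open, on these data alone, is whether the step would keep its size if the acyl group on the other side of the shared core were changed, for example to a morpholine-4-carbonyl group.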